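The source may report more compounds than this note shows. Statements on the series, on what has been measured and on what is new or still open speak of the compounds shown alone.

In a functional assay on NIH3T3 cells (Mus musculus) (a lower number here means that less compound is needed, a higher number that more compound is needed for the effect), compound 1 (`COC(=O)[C@H](CCSC)NC(=O)c1ccc(NCc2cncn2Cc2cccc([N+](=O)[O-])c2)cc1-c1ccccc1`) gives > 10 uM, which is a limit of the assay and not a number. Compound 2 (`COC(=O)[C@H](CCSC)NC(=O)c1ccc(NCc2cncn2Cc2ccc([N+](=O)[O-])cc2)cc1-c1ccccc1`) gives > 10 uM, also only a limit. Both therefore stand at the limit of > 10 uM in this assay, at which 2 of the 2 values shown sit. Compound 3 (`COC(=O)[C@H](CCSC)NC(=O)c1ccc(NCc2cncn2Cc2ccccc2Cl)cc1-c1ccccc1`) carries 2-chlorophenyl in place of 4-nitrophenyl on a saturated chain carbon bound to an aromatic nitrogen. Among the compounds with values here, the only measured step bearing on this is a step that the two limits leave unreadable from compound 1 to compound 2, so it offers no size or direction to carry over to this assay. The expected step is a step that the limit leaves unreadable from compound 2 to compound 3, with no clear change expected. Compound 3 is estimated at 12 uM, within an expected range of 3 uM to 30 uM.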

Compound 3, concentration for half-maximal effect: > 10 uM
Compound 3 gave a limit, no number; the forecaster's own chance of this, stated with the estimate: 70%; the middle value does not contradict the limit.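

Within the data shown here, compound 3 also gives only a limit, so no step among compound 1, compound 2 and compound 3 can be read: the limit of > 10 uM in this assay, at which 3 of the 3 values shown sit.

Going by these compounds, how far apart these three compounds truly lie in this assay remains open, as does whether changing this group has any effect.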